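Notes on a side chain at the aromatic nitrogen

A few compounds are considered here, and "the series" means these few. Any claim that something is new, unique, unknown or untested is made for them only; others in the source may bear on it.

Going by the values given here, in a functional assay on CCRF-CEM cells (Homo sapiens) for cytotoxicity (a lower number here means a stronger inhibitor, a higher number a weaker inhibitor), compound 1 (`Oc1ccc2[nH]c(-c3cncc(-c4cc5cc(O)ccc5[nH]4)c3)cc2c1`) gives 7990 nM and compound 2 (`Oc1ccc(-c2cncc(-c3cc4cc(O)ccc4[nH]3)c2)cc1`) gives 14500 nM as the only numbers so far. These two values lie within the usual scatter of each other, so the data do not separate the compounds.

Compound 3 (`CN(C)CCn1c(-c2cncc(-c3cc4cc(O)ccc4[nH]3)c2)cc2cc(O)ccc21`) keeps the core of compound 1 and carries 2-(dimethylamino)ethyl in place of hydrogen on an aromatic nitrogen, next to the ring atom that bears a large group. The counted change is 2-(dimethylamino)ethyl in place of hydrogen on an aromatic nitrogen and nothing else differs.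

Among the compounds with values here, neither measured compound carries a substituent on an aromatic nitrogen, and no measured pair shows a comparable change. The expectation in this assay therefore rests on the structural change alone and remains uncertain. A moderate move towards a lower number is expected, with a 2.7-fold lower number from compound 1 to compound 3 (0.43 log units; beyond the scatter) as the estimated step, though a result within the scatter of compound 1 would not be surprising. For compound 3 the estimate is 3000 nM with an expected range from 700 nM to 12000 nM at this stage.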

Compound 3, half-maximal inhibitory concentration: 5760 nM
The estimate for compound 3 lay 1.9-fold (0.28 log units) below the measured number; measured number inside the range.
By their numbers in this assay, from the lowest: compounds 3, 1 and 2 (each within the scatter of the next, the first and the last beyond it).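

In this assay, the first substitution at this position gives a 1.4-fold lower number from compound 1 to compound 3 (0.14 log units; within the scatter), with 2-(dimethylamino)ethyl in place of hydrogen on an aromatic nitrogen, so compound 3 and compound 1 are not separated. The earlier compounds shown here carry no substituent on an aromatic nitrogen and could say nothing about this site; this pair shows that, for this one chain, the hydrogen on this nitrogen can be replaced while the number stays within the scatter of compound 1. No supporting measurement accompanies this result, so the reading stops at the number itself.

From the compounds shown here alone, it remains open whether the same holds for other groups on this nitrogen, such as a methyl group, a longer chain ending in a dimethylamino group, a morpholine ring or a carboxylic acid, any of which could show whether this position responds to the group placed on it at all. Also open, going by these compounds, is whether 2-(dimethylamino)ethyl on the other aromatic nitrogen of compound 1, or on the aromatic nitrogen of compound 2, would leave the number within the scatter in the same way.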